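A few compounds are considered here, and "the series" means these few. Any claim that something is new, unique, unknown or untested is made for them only; others in the source may bear on it.

Compound 1 `O=C1N(CCCCCCOc2ccc(Cl)cc2)CCN1c1ccncc1` gives > 25000 nM in a functional assay on cells (Homo sapiens) for cytotoxicity (a higher number here means that more compound is tolerated, a lower number that less compound is tolerated), which is a limit of the assay and not a number.
Compound 2 `O=C1N(CCCCCCOc2cccc(Br)c2)CCN1c1ccncc1` gives > 25000 nM in this assay, again a limit.
Compound 3 `O=C1N(CCCCCCOc2c(Cl)cccc2Cl)CCN1c1ccncc1` gives > 25000 nM in this assay, also a limit.

All three measured compounds sit at the same limit (the limit of > 25000 nM in this assay, at which 3 of the 3 values shown sit), so compound 3 stands nowhere distinct from its two neighbours. The steps a step that the two limits leave unreadable from compound 1 to compound 2, a step that the two limits leave unreadable from compound 1 to compound 3 and a step that the two limits leave unreadable from compound 2 to compound 3 are all unreadable for this reason. Compound 4 `COc1ccc(OCCCCCCN2CCN(c3ccncc3)C2=O)c(Cl)c1` differs from compound 3 by 2-chloro-4-methoxyphenyl in place of 2,6-dichlorophenyl on an oxygen on a saturated carbon. Going by the values given here, the only measured steps that touch the same oxygen-linked aryl group, from compound 1 to compound 3 and from compound 2 to compound 3, carry no readable size, so no direction can be derived for this assay; the expectation is that compound 4 remains at the limit as well. Compound 4 is therefore estimated at 40000 nM, within 20000 nM to 100000 nM. This estimate corresponds to an expected step that the limit leaves unreadable from compound 3 to compound 4.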

Compound 4, half-maximal cytotoxic concentration: > 25000 nM
Compound 4: only a limit was reported; the forecaster's own chance of this, stated with the estimate: 85%; the middle value is on the limit's open side.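

The steps between compound 4 and compound 1, compound 2 and compound 3 cannot be read, as all four compounds share one limit: the limit of > 25000 nM in this assay, at which 4 of the 4 values shown sit.

The compounds shown leave open whether changing the aryl group on the oxygen affects the read-out at all in this assay.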